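Swapping the aryl group on the ring nitrogen of compound 3

A few compounds are considered here, and "the series" means these few. Any claim that something is new, unique, unknown or untested is made for them only; others in the source may bear on it.

Compound 1: `Cc1cc(=O)n(-c2ccccc2OC(F)(F)F)nc1C(=O)Nc1ccc(Oc2ncnc3ccsc23)c(F)c1`, 15700 nM
Compound 2: `Cc1cc(=O)n(-c2ccccc2OC(F)(F)F)nc1C(=O)Nc1ccc(Oc2ncnc3sccc23)cc1`, 14400 nM
Compound 3: `Cc1cc(=O)n(-c2ccc(Br)cc2F)nc1C(=O)Nc1ccc(Oc2ncnc3sccc23)c(F)c1`, 13800 nM

Of the compounds shown here, three sharing one core have been tested in a functional assay on HepG2 cells (Homo sapiens) for cytotoxicity, read by MTT assay, with a stated time of 72 h; on this read-out higher numbers stand for weaker inhibition and lower numbers for stronger inhibition. Compound 1 gives 15700 nM. Compound 2 gives 14400 nM. Compound 3 gives 13800 nM, and this number sits within the scatter of both compound 2 and compound 1, so the three cannot be told apart on this read-out; none of them is weaker or stronger than another in any meaningful sense.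

Compound 4, `Cc1cc(=O)n(-c2ccccc2OC(F)(F)F)nc1C(=O)Nc1ccc(Oc2ncnc3sccc23)c(F)c1`, has not yet been measured. It differs from compound 3 by 2-(trifluoromethoxy)phenyl in place of 4-bromo-2-fluorophenyl on an aromatic nitrogen. The group that enters is the same one that compound 1 and compound 2 already carry at that position, and both of them sit in the same narrow band as compound 3 in this assay.

Going by the values given here, no single-change step between measured compounds exists to set a scale for this particular swap. Given that compound 1 gives 15700 nM and compound 2 gives 14400 nM with the entering group in place, the expected step from compound 3 to compound 4 is a 1.1-fold higher number from compound 3 to compound 4 (0.04 log units; within the scatter), that is, no change beyond the scatter in either direction. Compound 4 is therefore estimated at 15000 nM, with a range from 7000 nM to 32000 nM.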

Compound 4, half-maximal inhibitory concentration: > 40000 nM
Compound 4 gave a limit, no number (the forecaster's own chance of this, stated with the estimate: 10%); at least 2.6-fold (0.42 log units) between middle value and limit.
By their numbers in this assay, from the lowest: compounds 3, 2 and 1 (each within the scatter of the next). At a limit, above all of these: compound 4.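

In this assay, going by these compounds alone, compound 4 gives a limit of the assay and not a number: the limit of > 40000 nM in this assay, at which 1 of the 4 values shown sits. Replacing 4-bromo-2-fluorophenyl with 2-(trifluoromethoxy)phenyl on the aromatic nitrogen gives an at least 2.8-fold higher number from compound 3 to compound 4 (0.46 log units; beyond the scatter), so this position can shift the read-out beyond the scatter, which the narrow band of the earlier compounds did not show. The entering group does not set this result alone, as compound 1 and compound 2 carry it too, yet fluoro in place of hydrogen on an aromatic carbon gives an at least 2.7-fold higher number from compound 2 to compound 4 (0.44 log units; beyond the scatter), and the exchange of one group for another of the same atom count on the oxygen gives an at least 2.5-fold higher number from compound 1 to compound 4 (0.40 log units; beyond the scatter).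

The compounds shown leave open whether the jump belongs to 2-(trifluoromethoxy)phenyl only in this exact combination with the other two parts of compound 4, or whether a plain phenyl or a 2-methoxyphenyl on the aromatic nitrogen would behave the same way. From the compounds shown here alone, the true size of all three steps also remains open, as each is known only as a minimum.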